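The source may hold more compounds than are shown below. What is called first, only, known or untested is meant among the compounds shown, and "the series" means these compounds.

Four close relatives share one core, and their ability to slow cell growth is read in a functional assay on MCF7 cells (Homo sapiens) for antiproliferative activity, read by MTT assay, with a stated time of 48 h; a lower number here means a stronger inhibitor, a higher number a weaker inhibitor. Compound 1 `O=C(CN1CCCC1)Nc1ccc2ncnc(Nc3ccc(Cl)cc3)c2c1` gives 16000 nM. Compound 2 `O=C(CN1CCCCC1)Nc1ccc2ncnc(Nc3ccc(Cl)cc3)c2c1` differs from it by piperidin-1-yl in place of pyrrolidin-1-yl on a saturated chain carbon bound to a carbonyl carbon. Compound 2 shows only a limit in this assay, namely > 100000 nM, and that is the limit of > 100000 nM in this assay, at which 1 of the 3 values shown sits. The step is an at least 6.2-fold higher number from compound 1 to compound 2 (0.79 log units; beyond the scatter). Compound 3 `O=C(CN1CCCC1)Nc1ccc2ncnc(Nc3cccc(Br)c3)c2c1` carries a different core from compound 1, the difference being (3-bromophenyl in place of 4-chlorophenyl on a nitrogen on an aromatic ring); in this assay compound 3 gives 12000 nM, a step of a 1.3-fold lower number from compound 1 to compound 3 (0.12 log units; within the scatter), so the two cores behave alike. Compound 4 `O=C(CN1CCCCC1)Nc1ccc2ncnc(Nc3cccc(Br)c3)c2c1` has not yet been measured. It differs from compound 3 by piperidin-1-yl in place of pyrrolidin-1-yl on a saturated chain carbon bound to a carbonyl carbon, the same change that separates compound 1 from compound 2, made at the same place. Because an at least 6.2-fold higher number from compound 1 to compound 2 (0.79 log units; beyond the scatter) went at least modestly toward a weaker inhibitor, the expected step from compound 3 to compound 4 is of a similar size, a 6.7-fold higher number from compound 3 to compound 4 (0.82 log units; beyond the scatter). On that basis compound 4 is estimated at 80000 nM, expected to fall between 30000 nM and 300000 nM, with a real chance that only a limit is reported.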

Compound 4, half-maximal inhibitory concentration: 3000 nM
Beside the measured number, compound 4's estimate is 27-fold (1.43 log units) above it; measured number below the stated range.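

In this assay, the swap of pyrrolidin-1-yl for piperidin-1-yl does not carry over from one core to the other: with the 3-bromophenyl group it gives a 4.0-fold lower number from compound 3 to compound 4 (0.60 log units; beyond the scatter), the opposite direction to its effect with the 4-chlorophenyl group, and the two steps differ: the same change on two cores in this assay, an at least 6.2-fold higher number (0.79 log units; beyond the scatter) from compound 1 to compound 2 and a 4.0-fold lower number (0.60 log units; beyond the scatter) from compound 3 to compound 4, at least 25-fold (1.39 log units) apart, beyond the scatter of two such steps Read the other way, the change from 4-chlorophenyl to 3-bromophenyl makes no clear difference with pyrrolidin-1-yl but gives an at least 33-fold lower number from compound 2 to compound 4 (1.52 log units; beyond the scatter) with piperidin-1-yl, so the two places in these compounds do not act independently: the same change on two cores in this assay, a 1.3-fold lower number (0.12 log units; within the scatter) from compound 1 to compound 3 and an at least 33-fold lower number (1.52 log units; beyond the scatter) from compound 2 to compound 4, at least 25-fold (1.39 log units) apart, beyond the scatter of two such steps This does not show why the effect reverses, and the reading for compound 2 is a limit rather than a number: the limit of > 100000 nM in this assay, at which 1 of the 4 values shown sits.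

The 3-bromophenyl and 4-chlorophenyl groups differ in both the halogen and where it sits, so 3-chlorophenyl and 4-bromophenyl partners would be needed to tell these apart. From the compounds shown here alone, it also remains open how another amine on the chain, such as morpholin-4-yl, would behave on either core.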